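Phenylsulfonyl for benzoyl on a pyridone-type series at one concentration

A few compounds are considered here, and "the series" means these few. Any claim that something is new, unique, unknown or untested is made for them only; others in the source may bear on it.

Measured compounds:
compound 1 `CC(=O)c1cc(C(=O)c2ccccc2)c(=O)[nH]c1C` gives 0%
compound 2 `O=C(c1ccccc1)c1cc(C(=O)c2ccccc2)c(=O)[nH]c1-c1ccccc1` gives 2%
compound 3 `CC(=O)c1cc(S(=O)(=O)c2ccccc2)c(=O)[nH]c1C` gives 0%

In an assay on CHO cells for displacement of a labelled ligand from adenosine receptor A3 (Homo sapiens), tested at 10 uM (on this read-out lower numbers stand for less inhibition and higher numbers for more inhibition at the one concentration tested (going by the name of the read-out)), compound 2 gives the highest of the three numbers, but its gap to compound 1 and its gap to compound 3 both lie within the usual scatter of repeated measurements, so no ordering among the three can be read from these values. Compound 4 `O=C(c1ccccc1)c1cc(S(=O)(=O)c2ccccc2)c(=O)[nH]c1-c1ccccc1` has not yet been measured. It differs from compound 2 in one place: phenylsulfonyl in place of benzoyl on an aromatic carbon. Among the compounds with values here, compound 1 and compound 3 share the same kind of exchange at the corresponding position; in this assay compound 1 shows 0% and compound 3 shows 0%, and no computed step between them is given here. With all three measured values essentially flat, no step beyond the scatter is expected in either direction from compound 2 to compound 4, and compound 4 is estimated at 1% in this assay, with a range from 0% to 10%. The expected step is therefore a number 1 percentage points lower from compound 2 to compound 4 (within the scatter).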

Compound 4, a percentage reported as inhibition, at one concentration (the size of the read-out at that concentration, not a potency): 0%
Beside the measured number, compound 4's estimate is 1 percentage points above it; the range from low to high includes it.
By their numbers in this assay, from the lowest: compounds 1, 3, 4 and 2 (each within the scatter of the next).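

With the shared core and the phenyl group kept, the exchange of benzoyl for phenylsulfonyl on this aromatic carbon, two atoms from the ring nitrogen, now comes with a readable step in this assay: a number 2 percentage points lower from compound 2 to compound 4 (within the scatter). Within the data shown here, the earlier pair gave no such step, with compound 1 at 0% and compound 3 at 0%, so this is the first sign that the position carries phenylsulfonyl, with its added sulfur and second hydrogen-bond acceptor, without the number leaving the flat range of the series. Nothing at hand bears on why the number stays there.

As far as these compounds go, whether an amine or a carboxylic acid at this position would lift the number out of that range stays open. So does the outcome of this exchange on a compound that starts with clear inhibition.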